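The compounds below may be only part of what the source reports. "The series", "measured", "known", "first", "only" and "open" are said of these compounds alone.

Three compounds built on a shared core have been examined in an ADME assay on HEK293 cells (Homo sapiens) for cytotoxicity, read by ATP content, with a stated time of 6 h; a higher number here means that more compound is tolerated, a lower number that less compound is tolerated. Compound 1 `CCCCNc1nc(N)nc2ccn(CC=C(C)C)c12` gives > 24000 nM, which is a limit of the assay rather than a number. Compound 2 `CCCCNc1nc(N)nc2ccn(Cc3nccs3)c12` likewise gives > 24000 nM, again a limit. Compound 3 `CCOCCNc1nc(N)nc2ccn(Cc3ccccn3)c12` gives > 24000 nM, also a limit. Within the data shown here, the one measured step, a step that the two limits leave unreadable from compound 1 to compound 2, cannot be sized because both of its ends sit at the limit of > 24000 nM in this assay, at which 3 of the 3 values shown sit. Compound 3 therefore stands at the same limit as the other two, with no numerical value to set it apart from them. Compound 4 `Nc1nc(NCc2ccon2)c2c(ccn2Cc2ccccn2)n1` differs from compound 3 by 1,2-oxazol-3-yl in place of ethoxymethyl on a saturated chain carbon bound to a nitrogen on an aromatic ring. Among the measured compounds shown here, no measured step involves this change, and the only step available is unreadable, so no direction and no size beyond the scatter can be drawn from the data. Compound 4 is expected to sit at the same limit, so the step that the limit leaves unreadable from compound 3 to compound 4 is estimated as none beyond the scatter. The value of compound 4 is estimated at 30000 nM, between 12000 nM and 80000 nM.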

Compound 4, half-maximal cytotoxic concentration: > 24000 nM
Compound 4: only a limit was reported (the forecaster's own chance of this, stated with the estimate: 85%); the middle value lies beyond the limit too.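

Compound 4 gives > 24000 nM, which is a limit of the assay and not a number, so no step can be read from compound 3 to compound 4: the limit of > 24000 nM in this assay, at which 4 of the 4 values shown sit.

The compounds shown leave open at what concentration any of them becomes cytotoxic, and whether changing their groups alters that concentration at all.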